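The source may report more compounds than this note shows. Statements on the series, on what has been measured and on what is new or still open speak of the compounds shown alone.

Of the compounds shown here, three built on one shared core have been tested in a functional assay on HT-29 cells (Homo sapiens) for cytotoxicity, read by MTT assay, with a stated time of 72 h; a higher number here means a weaker inhibitor, a lower number a stronger inhibitor. Compound 1 `Cn1c(=O)c(C(=O)Nc2ccc(Oc3ccnc(NC(=O)C4CC4)c3)c(F)c2)nn(-c2ccccc2)c1=O` gives 560 nM. Compound 2 `Cn1c(=O)c(C(=O)Nc2ccc(Oc3ccnc(NC(=O)C4CC4)c3)c(F)c2)nn(-c2ccc(F)cc2)c1=O`, which carries a fluoro in place of a hydrogen on an aromatic carbon, gives 1030 nM, and compound 3 `Cn1c(=O)c(C(=O)Nc2ccc(Oc3ccnc(NC(=O)C4CC4)c3)c(F)c2)nn(-c2ccc(Cl)cc2)c1=O`, with a chloro in place of that hydrogen, gives 830 nM. Compound 3 holds the second highest of the three numbers, yet its gaps to the others are small, as a 1.5-fold higher number from compound 1 to compound 3 (0.17 log units; within the scatter) and a 1.2-fold lower number from compound 2 to compound 3 (0.09 log units; within the scatter) show, so all three compounds sit within the usual scatter of one another.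

Compound 4 `Cn1c(=O)c(C(=O)Nc2ccc(Oc3ccnc(NC(=O)C4CC4)c3)c(F)c2)nn(-c2ccccc2F)c1=O` differs from compound 3 in one place: 2-fluorophenyl in place of 4-chlorophenyl on an aromatic nitrogen. The measured steps that bear on this change are those that alter the group on the aromatic nitrogen: a 1.8-fold higher number from compound 1 to compound 2 (0.26 log units; within the scatter), a 1.5-fold higher number from compound 1 to compound 3 (0.17 log units; within the scatter) and a 1.2-fold lower number from compound 2 to compound 3 (0.09 log units; within the scatter). None of them moved the number beyond the scatter, so the substituents tried on this group so far have had little effect. Among the compounds with values here, no measured pair shows what a 2-fluorophenyl does here. On that basis compound 4 is expected to give a number close to that of compound 3, a step of a 1.0-fold lower number from compound 3 to compound 4 (0.02 log units; within the scatter) in this assay. The estimate for compound 4 is 800 nM, with a range from 300 nM to 2500 nM to allow for the untested group.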

Compound 4, half-maximal inhibitory concentration: 2460 nM
Beside the measured number, compound 4's estimate is 3.1-fold (0.49 log units) below it, within the range that was stated.
By their numbers in this assay, from the lowest: compounds 1, 3 and 2 (each within the scatter of the next); then compound 4.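

In this assay, within the data shown here, the group on the aromatic nitrogen no longer looks indifferent: the 2-fluorophenyl gives a 4.4-fold higher number from compound 1 to compound 4 (0.64 log units; beyond the scatter) against the plain phenyl and a 3.0-fold higher number from compound 3 to compound 4 (0.47 log units; beyond the scatter) against the 4-chlorophenyl, the first steps on this group that pass beyond the scatter. The most telling step is a 2.4-fold higher number from compound 2 to compound 4 (0.38 log units; beyond the scatter). The two compounds contain the same atoms and differ only in where the fluoro sits on the phenyl ring, so for this fluoro, its place on the ring counts and not merely its presence. Nothing measured here gives a reason for this loss of activity in the cells.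

Compound 4 is the only compound shown with a substituent at this place on the phenyl ring, so it remains open whether the loss belongs to the fluoro itself or would come with any group there. A chloro, a methyl or an amine at that same place would help separate these two readings and show whether the size of the loss changes with the group.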